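Phenyl substituent swaps on the saturated ring carbon

The source may hold more compounds than are shown below. What is called first, only, known or untested is meant among the compounds shown, and "the series" means these compounds.

Three compounds of the series have been run in a functional assay on the whole organism (strain albino) with Rattus norvegicus as the target, in the maximal electroshock model, with a stated time of 1 h, at a dose of 30 mg/kg by the intraperitoneal route; on this read-out lower numbers stand for less inhibition and higher numbers for more inhibition at the one dose given (going by the name of the read-out). Compound 1 `Cc1nc2ccc(Br)cc2c(=O)n1NCc1nnc(N2C(=O)CSC2c2ccc(O)cc2)s1` gives 60%. Compound 2 `COc1cccc(C2SCC(=O)N2c2nnc(CNn3c(C)nc4ccc(Br)cc4c3=O)s2)c1` gives 60%, and compound 3 `Cc1nc2ccc(Br)cc2c(=O)n1NCc1nnc(N2C(=O)CSC2c2ccc(N(C)C)cc2)s1` gives 60%. The three read-outs sit together: no change at the digits printed from compound 1 to compound 2 (within the scatter), no change at the digits printed from compound 1 to compound 3 (within the scatter), and no change at the digits printed from compound 2 to compound 3 (within the scatter). Compound 3 thus stands level with compounds 1 and 2, with compound 1 its nearest and compound 2 its furthest neighbour on the digits shown, and neither gap leaves the scatter.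

The next compound, compound 4 `COc1cc(C2SCC(=O)N2c2nnc(CNn3c(C)nc4ccc(Br)cc4c3=O)s2)ccc1O`, is not yet measured. Compared with compound 3 the change is 4-hydroxy-3-methoxyphenyl in place of 4-(dimethylamino)phenyl on a saturated ring carbon. The entering group carries the hydroxy seen in compound 1 and the methoxy seen in compound 2 on the same phenyl.

All three measured steps bear on this change, since each swaps one phenyl substitution pattern for another on the saturated ring carbon, and each came out flat within the scatter. A hydroxy, a methoxy and a dimethylamino have each left this read-out untouched. The expected step of no change at the digits printed from compound 3 to compound 4 (within the scatter) is therefore none beyond the scatter. For compound 4 the estimate in this assay is 60%, with a range from 45% to 75%.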

Compound 4, a percentage reported as inhibition, in the whole organism at one dose (the size of the read-out at that dose, not a potency): 60%
Beside the measured number, compound 4's estimate shows no gap at the digits printed; the range from low to high includes it.
By their numbers in this assay, from the lowest: compounds 1, 2, 3 and 4 (each within the scatter of the next).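

In this assay, hydroxy and methoxy carried together on one phenyl read the same as either carried alone: hydroxy in place of hydrogen on an aromatic carbon gives no change at the digits printed from compound 2 to compound 4 (within the scatter) and methoxy in place of hydrogen on an aromatic carbon gives no change at the digits printed from compound 1 to compound 4 (within the scatter) on the saturated ring carbon of the shared core. The exchange of 4-(dimethylamino)phenyl for 4-hydroxy-3-methoxyphenyl, the only phenyl here with two substituents, gives no change at the digits printed from compound 3 to compound 4 (within the scatter) at this one dose, so the flat picture at this position now extends from single substituents to a pair on the same ring. Nothing available here accounts for this flatness at the position.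

With all four compounds level at a single dose, the read-out offers no ranking among these phenyl patterns and does not show how far the position can be changed before this assay moves. Still open, from the compounds shown here alone, are a carboxylic acid, a primary amine or a longer chain such as butoxy on the phenyl, and a plain methyl in place of the whole phenyl on the saturated ring carbon.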